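From a Cyanophenyl to a Difluorophenyl Group

The source may report more compounds than this note shows. Statements on the series, on what has been measured and on what is new or still open speak of the compounds shown alone.

Three measured compounds share one core and differ only in the aryl group attached to an aromatic carbon of a five-membered aromatic ring with 2 nitrogen. In an assay for displacement of a labelled ligand from melanin-concentrating hormone receptor 1 (Homo sapiens), read by fluorescence (on this read-out higher numbers stand for weaker inhibition and lower numbers for stronger inhibition), compound 1 `CC(=O)Nc1cccc(C2CCN(CCCn3c(-c4cccc(Cl)c4)nc4ccccc43)CC2)c1` gives 5 nM, compound 2 `COc1ccccc1-c1nc2ccccc2n1CCCN1CCC(c2cccc(NC(C)=O)c2)CC1` gives 747 nM, and compound 3 `CC(=O)Nc1cccc(C2CCN(CCCn3c(-c4ccc(C#N)cc4)nc4ccccc43)CC2)c1` gives 16 nM. Compound 3 therefore stands second highest of the three numbers, framed by a 3.2-fold higher number from compound 1 to compound 3 (0.51 log units; beyond the scatter) on one side and a 47-fold lower number from compound 2 to compound 3 (1.67 log units; beyond the scatter) on the other. Compound 4 `CC(=O)Nc1cccc(C2CCN(CCCn3c(-c4ccc(F)c(F)c4)nc4ccccc43)CC2)c1` has not yet been measured; it differs from compound 3 in that (3,4-difluorophenyl in place of 4-cyanophenyl on an aromatic carbon). The steps bearing on this change are those at the same aromatic carbon: a 3.2-fold higher number from compound 1 to compound 3 (0.51 log units; beyond the scatter) was modest, whereas a 150-fold higher number from compound 1 to compound 2 (2.17 log units; beyond the scatter) and a 47-fold lower number from compound 2 to compound 3 (1.67 log units; beyond the scatter) were large. Among the compounds with values here, the 3-chlorophenyl group of compound 1, which gave 5 nM, is the nearest precedent for a 3,4-difluorophenyl group. On that basis compound 4 is expected to show a 2.0-fold lower number from compound 3 to compound 4 (0.30 log units; within the scatter) in this assay, a small move toward lower numbers that may not exceed the scatter. The estimate for compound 4 is 8 nM, with a range from 2.5 nM to 25 nM.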

Compound 4, half-maximal inhibitory concentration: 4 nM
Compound 4: the middle estimate sits 2.0-fold (0.30 log units) above what was measured; the measured number falls inside the stated range.
By their numbers in this assay, from the lowest: compounds 4 and 1 (each within the scatter of the next); then compound 3; then compound 2.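

In this assay, the 3,4-difluorophenyl group gives a 4.0-fold lower number from compound 3 to compound 4 (0.60 log units; beyond the scatter) and a 190-fold lower number from compound 2 to compound 4 (2.27 log units; beyond the scatter), so this aromatic carbon accepts a second halogen-bearing phenyl group in place of the 4-cyanophenyl and 2-methoxyphenyl groups. With a 1.3-fold lower number from compound 1 to compound 4 (0.10 log units; within the scatter), the 3,4-difluorophenyl and 3-chlorophenyl groups cannot be told apart here, and among these four compounds the two halogen-bearing phenyl groups give the lowest numbers, with compound 3 and compound 2 both higher. No evidence is available to explain these differences.

As far as these compounds go, whether both fluorine atoms are required remains open, as does how a monofluorophenyl, a pyridyl or a cyclohexyl group would read at this position. The compounds shown also leave open whether the same order would hold if the acetamide on the shared core were replaced by an amine or a carboxylic acid.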